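This account rests on a few compounds, and the source may have more. Where it says the series, first, only, none or still open, it means among the compounds named here.

Values measured in a physicochemical assay for lipophilicity; on this read-out lower numbers stand for lower lipophilicity and higher numbers for higher lipophilicity:

Compound 1 `C[C@H]1CC[C@@H]2[C@@H](OC(=O)[C@]23CC(c2ccccc2Br)=NO3)[C@]2(C)C(=O)C=C[C@@]12O`: 2.22
Compound 2 `Cc1ccc(C2=NO[C@]3(C2)C(=O)O[C@@H]2[C@H]3CC[C@H](C)[C@]3(O)C=CC(=O)[C@@]23C)cc1`: 1.86
Compound 3 `COc1ccc(C2C[C@@]3(ON2c2ccccc2)C(=O)O[C@@H]2[C@H]3CC[C@H](C)[C@]3(O)C=CC(=O)[C@@]23C)cc1`: 3.25

Compound 3 stands highest of the three in this assay, with compound 1 nearest and compound 2 furthest, both separated from it by more than the scatter. Compound 4 `C[C@H]1CC[C@@H]2[C@@H](OC(=O)[C@]23CC(c2ccccc2Cl)N(c2ccccc2)O3)[C@]2(C)C(=O)C=C[C@@]12O` differs from compound 3 in one place: 2-chlorophenyl in place of 4-methoxyphenyl on a saturated ring carbon. For the measured compounds named here, the only step that bears on this swap is a number 0.36 log units lower from compound 1 to compound 2 (beyond the scatter), a modest change when a halogen-bearing phenyl gave way to a methylphenyl. Here a halogen-bearing phenyl enters instead, so a modest step upward beyond the scatter is expected, a number 0.40 log units higher from compound 3 to compound 4 (beyond the scatter). For compound 4 the expected value in this assay is 3.65, with a likely range from 3.2 to 4.1.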

Compound 4, partition coefficient: 3.87
Compound 4: the middle estimate sits 0.22 log units below what was measured; low and high end bracket the measured number.
By their numbers in this assay, from the lowest: compound 2; then compound 1; then compound 3; then compound 4.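

In this assay, the saturated ring carbon next to the ring nitrogen responds to the choice of aryl group: 2-chlorophenyl in place of 4-methoxyphenyl gives a number 0.62 log units higher from compound 3 to compound 4 (beyond the scatter). Together with the earlier step on the carbon with a double bond to nitrogen, this makes two pairs in which the halogen-bearing compound has the higher number, though the rings and partner groups differ. Nothing shown accounts for the size of this step.

The swap changes both the substituent and its place on the phenyl, and these two changes remain unseparated. Going by these compounds, how this ring carbon would respond to an amine or a carboxylic acid also remains open.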